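This account rests on a few compounds, and the source may have more. Where it says the series, first, only, none or still open, it means among the compounds named here.

Compound 1 `C=C[C@@](C)(/C=C/c1ccc(OC(C)=O)cc1)CCC=C(C)C`: 81%
Compound 2 `C=C[C@@](C)(/C=C/c1ccc(OC(=O)CC)cc1)CCC=C(C)C`: 60%

Within the data shown here, in a functional assay on THP-1 cells (Homo sapiens) for inhibition, with a stated time of 48 h, tested at 50 uM (on this read-out lower numbers stand for less inhibition of growth and higher numbers for more inhibition of growth at the one concentration tested), compound 2 gives 60%, the lower of the two numbers measured so far, while compound 1 gives 81%. The next compound, compound 3 `C=C[C@@](C)(/C=C/c1ccc(OC(=O)CCC)cc1)CCC=C(C)C`, differs from compound 2 by one change: methyl in place of hydrogen on a saturated chain carbon, two bonds along the chain from a carbonyl carbon. In words, this places methyl in place of hydrogen on a saturated chain carbon, two bonds along the chain from a carbonyl carbon, taking propanoyl to propylcarbonyl.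

Among the measured compounds shown here, only one measured step bears on this change. It is a number 21 percentage points lower from compound 1 to compound 2 (beyond the scatter), a modest fall beyond the scatter, produced by methyl in place of hydrogen on a saturated chain carbon bound to a carbonyl carbon. A single step establishes no trend, and the new methyl sits one bond further out, so the earlier fall may not carry over in full. A further, smaller fall is therefore expected. The estimated change is a number 10 percentage points lower from compound 2 to compound 3 (within the scatter). For compound 3, the expected value is 50%, with an estimated range from 30% to 70%.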

Compound 3, percent growth inhibition at one concentration: 54%
The estimate for compound 3 lay 4 percentage points below the measured number, within the range that was stated.
By their numbers in this assay, from the lowest: compounds 3 and 2 (each within the scatter of the next); then compound 1.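

In this assay, methyl in place of hydrogen on a saturated chain carbon, two bonds along the chain from a carbonyl carbon, gives a number 6 percentage points lower from compound 2 to compound 3 (within the scatter), so taking propanoyl to propylcarbonyl produces a step that cannot be told from the scatter, unlike the earlier step at the carbon bound to the carbonyl carbon. Measured from compound 1, propylcarbonyl gives a number 27 percentage points lower from compound 1 to compound 3 (beyond the scatter), which shows that the larger group also leaves the number beyond the scatter from that of compound 1, while the added methyl of compound 3 cannot be separated from compound 2. The compounds shown offer no measurement that accounts for either step.

On these data alone, it remains open whether a longer chain than propylcarbonyl, or a branched chain of the same length, would stay within the scatter of compound 3 or move the number further. Also open, as far as these compounds go, is how an amine or a carboxylic acid at the end of this chain would read, and, with a single tested concentration, how these compounds would compare across a range of concentrations.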